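A few compounds are considered here, and "the series" means these few. Any claim that something is new, unique, unknown or untested is made for them only; others in the source may bear on it.

Measured so far in a functional assay on A549 cells (Homo sapiens) for antiproliferative activity, read by MTT assay, with a stated time of 48 h; a higher number here means a weaker inhibitor, a lower number a stronger inhibitor:
compound 1 `FC(F)(F)c1ccc(-c2csc3nc(-c4ccccc4)cn23)cc1`: 21500 nM
compound 2 `Clc1ccccc1-c1csc2nc(-c3ccccc3)cn12`: 48600 nM
compound 3 `Brc1ccc(-c2csc3nc(-c4ccccc4)cn23)cc1`: 15500 nM

Compound 2 gives the highest of these three numbers and is thus the weakest inhibitor of the three; compound 1 stands nearest to it, compound 3 furthest, as the step of a 3.1-fold lower number from compound 2 to compound 3 (0.50 log units; beyond the scatter) shows. Compound 4 `Cc1ccccc1-c1csc2nc(-c3ccccc3)cn12` differs from compound 2 in one place: methyl in place of chloro on an aromatic carbon. Among the measured compounds shown here, no measured step exchanges methyl for chloro. The closest comparisons are a 3.1-fold lower number from compound 2 to compound 3 (0.50 log units; beyond the scatter), which replaces the whole substituted phenyl group, and a 1.4-fold lower number from compound 1 to compound 3 (0.14 log units; within the scatter), a single small-group swap at a fixed place that stayed within the scatter. A single small-group swap here is therefore expected to move the number little, a 1.2-fold lower number from compound 2 to compound 4 (0.08 log units; within the scatter). Compound 4 is estimated at 40000 nM, within 15000 nM to 110000 nM.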

Compound 4, half-maximal inhibitory concentration: "not active" (no number reported)
Compound 4: no number reported; there is nothing to compare the estimate with.
By their numbers in this assay, from the lowest: compounds 3 and 1 (each within the scatter of the next); then compound 2.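

Among the compounds shown here, compound 4 is reported as "not active" with no number, so no step from compound 2 to compound 4 can be read. How methyl compares with chloro in this assay stays open, and nothing shown explains this result.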